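The compounds below may be only part of what the source reports. "The series", "measured", "known", "first", "only" and "open" are said of these compounds alone.

Measured so far:
- compound 1 `CC(CC(=O)O)N1Cc2ccc(NC(=O)CCCC3CCNCC3)cc2C1=O` — in a functional assay on a cell-free system (Platelet, plasma, Homo sapiens) for inhibition (a higher number here means a weaker inhibitor, a lower number a stronger inhibitor), compound 1 gives 5400 nM
- compound 2 `CC(CC(=O)O)N1Cc2ccc(NC(=O)c3ccc4c(c3)CNCC4)cc2C1=O` — in this assay compound 2 gives 86 nM
- compound 3 `O=C(O)CCCN1Cc2ccc(NC(=O)CCCC3CCNCC3)cc2C1=O` — in this assay compound 3 gives 51000 nM

Compound 2 stands lowest of the three, and its steps to compound 1 and compound 3 are both beyond the scatter. Compound 1 and compound 2 differ in more than one place, so the difference between their two cores is not broken down here. Compound 1 and compound 3 share a core and differ in a single spot: 3-carboxypropyl in place of 1-(carboxymethyl)ethyl on an amide-type nitrogen in a ring. That change gave a 9.4-fold higher number from compound 1 to compound 3 (0.98 log units; beyond the scatter), a step beyond the scatter in the direction of weaker inhibition.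

Compound 4 `O=C(O)CCCN1Cc2ccc(NC(=O)c3ccc4c(c3)CNCC4)cc2C1=O` is not yet measured. It stands to compound 2 as compound 3 stands to compound 1: 3-carboxypropyl in place of 1-(carboxymethyl)ethyl on an amide-type nitrogen in a ring. The place is the same in both pairs, so this is the same change on a different core. Going by the values given here, the expectation for compound 4 rests on that one earlier step, because a 9.4-fold higher number from compound 1 to compound 3 (0.98 log units; beyond the scatter) is the only measure of this change available. The estimated step is an 8.1-fold higher number from compound 2 to compound 4 (0.91 log units; beyond the scatter). The estimate for compound 4 in this assay is 700 nM, with a range from 200 nM to 2500 nM.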

Compound 4, half-maximal inhibitory concentration: 330000 nM
Compound 4: middle estimate off by 470-fold (2.67 log units), on the low side, and the stated range ends below it.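

In this assay, putting 3-carboxypropyl in place of 1-(carboxymethyl)ethyl on the amide-type nitrogen gives a 3800-fold higher number from compound 2 to compound 4 (3.58 log units; beyond the scatter). The direction of the change carried over, with weaker inhibition on both cores, but its size did not, and the two steps differ by more than ordinary scatter: the same change on two cores in this assay, a 9.4-fold higher number (0.98 log units; beyond the scatter) from compound 1 to compound 3 and a 3800-fold higher number (3.58 log units; beyond the scatter) from compound 2 to compound 4, 410-fold (2.61 log units) apart, beyond the scatter of two such steps. A step measured on one core therefore cannot be used as a numerical forecast for another core in this series, and these two pairs show neither why the cores respond so differently nor how a third core would respond.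

The compounds shown leave open how a longer chain ending in a carboxylic acid, or a methyl ester in place of that acid, would behave on either core. They also leave open whether such changes would again differ so widely in size between the two cores.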